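Chloro on the aminoheteroaryl group of the cyanophenylpyrazole series

The compounds below may be only part of what the source reports. "The series", "measured", "known", "first", "only" and "open" are said of these compounds alone.

Compound 1 `C[C@@H](Cn1ccc(-c2ccc(C#N)c(Cl)c2)n1)Nc1ncccn1` carries an unsubstituted pyrimidin-2-yl on the amine nitrogen. In a functional assay on VCaP cells (Homo sapiens) for antiproliferative activity, read by CCK-8 assay, with a stated time of 6 days (a lower number here means a stronger inhibitor, a higher number a weaker inhibitor), compound 1 gives 480 nM. Compound 2 `C[C@@H](Cn1ccc(-c2ccc(C#N)c(Cl)c2)n1)Nc1nccc(Cl)n1` differs from it by chloro in place of hydrogen on an aromatic carbon. For compound 2 the assay reports only a limit, > 30000 nM, which is the limit of > 30000 nM in this assay, at which 1 of the 3 values shown sits. The step of an at least 62-fold higher number from compound 1 to compound 2 (1.79 log units; beyond the scatter) is accordingly large. Compound 3 `C[C@@H](Cn1ccc(-c2ccc(C#N)c(Cl)c2)n1)Nc1ncnc2nc[nH]c12` has a different group on the amine nitrogen; the difference between the two cores is a group of 9 heavy atoms (5 carbon, 4 nitrogen; one five-membered aromatic ring with 2 hetero atoms, one six-membered aromatic ring with 2 hetero atoms) in place of a group of 6 heavy atoms (4 carbon, 2 nitrogen; one six-membered aromatic ring with 2 hetero atoms), on an amine nitrogen. In this assay compound 3 gives 640 nM, and the step of a 1.3-fold higher number from compound 1 to compound 3 (0.12 log units; within the scatter) lies within the scatter, so the two cores behave alike here.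

Compound 4 `C[C@@H](Cn1ccc(-c2ccc(C#N)c(Cl)c2)n1)Nc1nc(Cl)nc2nc[nH]c12` is not yet measured and differs from compound 3 by chloro in place of hydrogen on an aromatic carbon. This is the same kind of change as from compound 1 to compound 2, but the surroundings differ: in compound 2 the chloro sits next to the ring nitrogen, meta to a large group and opposite the ring nitrogen, whereas in compound 4 it sits between two ring nitrogen atoms, meta to a fused ring, meta to a large group and para to a fused ring.

Resting on the single measured instance an at least 62-fold higher number from compound 1 to compound 2 (1.79 log units; beyond the scatter), the expected step in this assay is a 23-fold higher number from compound 3 to compound 4 (1.37 log units; beyond the scatter), a large loss, though with one example ending in a limit its size is uncertain. Compound 4 is estimated at 15000 nM, with a range from 2500 nM to 60000 nM, and a real chance that this assay again reports only a limit.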

Compound 4, half-maximal inhibitory concentration: 2700 nM
Beside the measured number, compound 4's estimate is 5.6-fold (0.74 log units) above it; low and high end bracket the measured number.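

Carrying chloro in place of hydrogen on an aromatic carbon to the core of compound 3 keeps the direction of the change in this assay, with a 4.2-fold higher number from compound 3 to compound 4 (0.63 log units; beyond the scatter), but the size of the step does not carry over: the same change on two cores in this assay, an at least 62-fold higher number (1.79 log units; beyond the scatter) from compound 1 to compound 2 and a 4.2-fold higher number (0.63 log units; beyond the scatter) from compound 3 to compound 4, at least 14-fold (1.17 log units) apart, beyond the scatter of two such steps. Compound 2 is recorded only as a limit: the limit of > 30000 nM in this assay, at which 1 of the 4 values shown sits. The two unsubstituted compounds lie within the scatter of each other, with a 1.3-fold higher number from compound 1 to compound 3 (0.12 log units; within the scatter), so the cores match without the chloro and part ways with it, yet a single pair on each core shows neither what sets the two steps apart nor how large the step would be on a further core; for now, the direction holds across compounds 2 and 4, while a size read from one core is a poor guide to the other.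

The chloro also stands in a different place in each pair, so the compounds shown leave open whether the core itself or the place of the substituent governs the size of the step. Also open, as far as these compounds go, is whether a smaller or differently built group on the same carbon, such as fluoro, methoxy or an amine, would follow the chloro on both cores.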